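The source may report more compounds than this note shows. Statements on the series, on what has been measured and on what is new or still open speak of the compounds shown alone.

For the measured compounds named here, compound 2 `O=C(c1ccc(OCCCN2CC[C@H](NS(=O)(=O)c3ccccc3)C2)cc1)C1CC1` gives 1200 nM in an assay on isolated protein for binding affinity to histamine H2 receptor (Homo sapiens) (a higher number here means a weaker inhibitor, a lower number a stronger inhibitor), the lowest of the two numbers in hand, although its only neighbour, compound 1 `O=C(c1ccc(OCCCN2CC[C@H](NS(=O)(=O)c3ccccc3F)C2)cc1)C1CC1`, which gives 1550 nM, lies within the scatter of it. Going by the values given here, the single measured step, a 1.3-fold lower number from compound 1 to compound 2 (0.11 log units; within the scatter), was within the scatter. Compound 3 `O=C(c1ccc(OCCCN2CC[C@H](NS(=O)(=O)c3ccc(Cl)cc3)C2)cc1)C1CC1` differs from compound 2 by chloro in place of hydrogen on an aromatic carbon. Among the compounds with values here, the only step that bears on this change is the measured one, which also exchanged a substituent on an aromatic carbon and was small; nothing in hand shows what a chloro group does at the place it occupies in compound 3, so the expectation rests on that one small step and carries a wide range. Compound 3 is therefore expected to give about 1000 nM, between 300 nM and 3500 nM, so that the expected step of a 1.2-fold lower number from compound 2 to compound 3 (0.08 log units; within the scatter) stays within the scatter.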

Compound 3, inhibition constant: 290 nM
For compound 3 the middle estimate is 3.4-fold (0.54 log units) above the measured one; measured number below the stated range.
By their numbers in this assay, from the lowest: compound 3; then compounds 2 and 1 (each within the scatter of the next).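

On the phenyl group at the sulfonyl sulfur, a single added atom can shift the result in this assay: chloro on an aromatic carbon, para to a large group, brings a 4.1-fold lower number from compound 2 to compound 3 (0.62 log units; beyond the scatter), whereas the earlier exchange of fluoro and hydrogen on that ring stayed within the scatter. Exchanging the whole aryl group, 4-chlorophenyl in place of 2-fluorophenyl, brings a 5.3-fold lower number from compound 1 to compound 3 (0.73 log units; beyond the scatter), which makes compound 3 the strongest of the three, since its steps to both others lie beyond the scatter. Nothing in hand explains this gain.

On these data alone, it remains open whether methyl, methoxy or trifluoromethyl at this same place would match chloro. As far as these compounds go, it also remains open whether chloro on another aromatic carbon of that ring would give a similar step, or whether a fluoro or bromo at this place would.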